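The compounds below may be only part of what the source reports. "The series", "measured", "known", "first", "only" and "open" are said of these compounds alone.

For the measured compounds named here, in an ADME assay on L02 cells (Homo sapiens) for cytotoxicity, read by MTT assay, with a stated time of 24 h (on this read-out higher numbers stand for weaker inhibition and lower numbers for stronger inhibition), three compounds with a shared core have numbers so far. Compound 1 (`COc1ccc(/C=C2\CN(C)C/C(=C\c3ccccc3F)C2=O)cc1`) gives 22100 nM, compound 2 (`COc1cc(/C=C2\CN(C)C/C(=C\c3ccccc3F)C2=O)cc(OC)c1OC`) gives 12100 nM, and compound 3 (`COc1cc(/C=C2\CN(C)C/C(=C\c3ccc(Br)cc3)C2=O)cc(OC)c1`) gives 21300 nM. Compound 3 thus lies within the usual scatter of both others, and the three values cannot be ranked. Compound 4 (`COc1cc(/C=C2\CN(C)C/C(=C\c3ccc(C#N)cc3)C2=O)cc(OC)c1`) differs from compound 3 in one place: cyano in place of bromo on an aromatic carbon. It carries cyano in place of bromo on an aromatic carbon, para to a large group. Going by the values given here, no measured pair shows this change, so no step beyond the scatter is expected in this assay, in either direction. The estimated change, a 1.1-fold lower number from compound 3 to compound 4 (0.03 log units; within the scatter), is therefore small. Compound 4 is expected at about 20000 nM, within a range of 9000 nM to 42000 nM.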

Compound 4, half-maximal inhibitory concentration: 14000 nM
The estimate for compound 4 lay 1.4-fold (0.15 log units) above the measured number; the measured number falls inside the stated range.
By their numbers in this assay, from the lowest: compounds 2, 4, 3 and 1 (each within the scatter of the next).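

For the compounds shown here, compounds 3 and 4 form the only pair here that differs in one place, and in this assay cyano in place of bromo on this aromatic carbon gives a 1.5-fold lower number from compound 3 to compound 4 (0.18 log units; within the scatter) and thus no step beyond the scatter. This position therefore accepts 4-cyanophenyl in place of 4-bromophenyl without a clear change in the number. Nothing measured here bears on the reason for this result. The compounds shown leave open whether an amine or a carboxylic acid on this aromatic carbon would shift the number beyond the scatter. They also leave open whether the same change reads alike on other substitution patterns of the shared core.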